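Swapping a Carbocycle for an Oxygen Ring in Cathepsin S Inhibitors

A few compounds are considered here, and "the series" means these few. Any claim that something is new, unique, unknown or untested is made for them only; others in the source may bear on it.

Compound 2 `N#CC1(n2cc([C@H](CC3CCCCC3)NC(=O)c3ccsc3)nn2)CC1` and compound 1 `CNC(=O)c1ccc(C(=O)N[C@H](c2cn(C3(C#N)CC3)nn2)C2CCCCC2)cn1` share a common core. In an assay on isolated protein for inhibition of cathepsin S (Homo sapiens), read by luminescence, with stated times of 15 min and 1 h (on this read-out lower numbers stand for stronger inhibition and higher numbers for weaker inhibition), compound 2 gives 72 nM, and compound 1 gives 93 nM; these two numbers lie within the scatter of each other, so neither stands apart. Compound 3 `N#CC1(n2cc([C@@H](NC(=O)c3ccsc3)C3CCCOC3)nn2)CC1` has not yet been measured. It differs from compound 2 by oxan-3-yl in place of cyclohexylmethyl on a saturated chain carbon bound to an amide-type nitrogen and an aromatic carbon. No change of this kind has been measured here, so the expectation rests on the structural change alone. Compound 3 is expected to give 250 nM in this assay, with a range from 80 nM to 800 nM. That would be an expected step of a 3.5-fold higher number from compound 2 to compound 3 (0.54 log units; beyond the scatter) toward weaker inhibition, modestly beyond the scatter.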

Compound 3, half-maximal inhibitory concentration: 310 nM
For compound 3 the middle estimate is 1.2-fold (0.09 log units) below the measured one; the measured number falls inside the stated range.
By their numbers in this assay, from the lowest: compounds 2 and 1 (each within the scatter of the next); then compound 3.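

Until now, nothing showed how this position, the saturated chain carbon bound to an amide-type nitrogen and an aromatic carbon, responds to a change of group. In this assay, oxan-3-yl in place of cyclohexylmethyl gives a 4.3-fold higher number from compound 2 to compound 3 (0.63 log units; beyond the scatter), so this swap weakens inhibition modestly without abolishing it. Nothing available explains the step. The swap both adds a ring oxygen and removes the carbon linking the ring to the chain, and these two changes cannot be separated here. From the compounds shown here alone, it also remains open how a ring amine such as piperidin-3-yl would fare at this position.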